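Changing the aryl group on a brominated growth inhibitor

A few compounds are considered here, and "the series" means these few. Any claim that something is new, unique, unknown or untested is made for them only; others in the source may bear on it.

- Compound 1 `O=S(=O)(/C=C/c1ccc(Cl)c(Cl)c1)Cc1ccc(Nc2ncnc3ccccc23)cc1` gives 41000 nM
- Compound 2 `O=S(=O)(/C=C/c1ccc(F)cc1Cl)Cc1ccc(Nc2ncnc3ccccc23)cc1` gives 100000 nM
- Compound 3 `O=S(=O)(/C=C/c1ccc(Cl)c(Cl)c1)Cc1ccc(Nc2ncnc3ccc(Br)cc23)cc1` gives 5000 nM

All three values come from a functional assay on SW-620 cells (Homo sapiens); a lower number here means a stronger inhibitor of growth, a higher number a weaker inhibitor of growth. Compound 3 has the lowest number of the three, and its steps to both of the others are beyond the scatter, so it is the strongest growth inhibitor measured so far.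

Compound 4 `O=S(=O)(/C=C/c1ccc(C(F)(F)F)cc1F)Cc1ccc(Nc2ncnc3ccc(Br)cc23)cc1` keeps the bromo group of compound 3 but differs in one place: 2-fluoro-4-(trifluoromethyl)phenyl in place of 3,4-dichlorophenyl on a double-bonded chain carbon bound to a double-bonded chain carbon. In words, 2-fluoro-4-(trifluoromethyl)phenyl stands in place of 3,4-dichlorophenyl on a double-bonded chain carbon bound to a double-bonded chain carbon.

The closest guide is a 2.4-fold higher number from compound 1 to compound 2 (0.39 log units; beyond the scatter), a modest step beyond the scatter, in which the same 3,4-dichlorophenyl group was replaced by a different group, 2-chloro-4-fluorophenyl. The other measured step, an 8.2-fold lower number from compound 1 to compound 3 (0.91 log units; beyond the scatter), concerns the bromo group, which compound 3 and compound 4 share, so it does not apply directly. Among the measured compounds shown here, no measured compound carries the new group, so the guide is only loose. A modest rise in the number, meaning weaker growth inhibition, is therefore expected in this assay. The expected change is a 2.4-fold higher number from compound 3 to compound 4 (0.38 log units; beyond the scatter). For compound 4 the estimated value is 12000 nM, with an expected range from 3000 nM to 50000 nM.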

Compound 4, concentration for 50% growth inhibition: 55000 nM
For compound 4 the middle estimate is 4.6-fold (0.66 log units) below the measured one, and the stated range ends below it.
By their numbers in this assay, from the lowest: compound 3; then compounds 1, 4 and 2 (each within the scatter of the next, the first and the last beyond it).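

Replacing the aryl group matters even when the bromo group is present: in this assay the change from 3,4-dichlorophenyl to 2-fluoro-4-(trifluoromethyl)phenyl gives an 11-fold higher number from compound 3 to compound 4 (1.04 log units; beyond the scatter) and counts as a large step, whereas the earlier replacement at this place, which brought in a different group on the core without bromo, gives a 2.4-fold higher number from compound 1 to compound 2 (0.39 log units; beyond the scatter) and counts as a modest one. Both replacements raise the number, so in these two pairs 3,4-dichlorophenyl gives the stronger growth inhibition, and the bromo group shared by compound 3 and compound 4 does not preserve the low number of compound 3 once that aryl group is gone. Nothing available explains why the new group, with its larger count of heavy atoms, weakens growth inhibition so much.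

As far as these compounds go, it remains open how 2-fluoro-4-(trifluoromethyl)phenyl would behave on the core without bromo, so it cannot yet be said whether the effects of the two places simply add. Also open, from the compounds shown here alone, is whether a phenyl group carrying an amine or a carboxylic acid at this place could bring the number below that of compound 3.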